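Swapping the pyrazole of compound 1 for a substituted one

The source may report more compounds than this note shows. Statements on the series, on what has been measured and on what is new or still open speak of the compounds shown alone.

Compound 1 `C[C@@H]1CCCN1c1c(C#N)c2c(N)nc(Nc3cn[nH]c3)nc2n1C` gives the lowest number of the three measured compounds in an assay on isolated protein for inhibition of Leucine-rich repeat serine/threonine-protein kinase 2 variant G2019S (Homo sapiens), read by TR-FRET and LanthaScreen, with stated times of 50 min and 30 min, in the presence of a further agent that is not named here (on this read-out lower numbers stand for stronger inhibition and higher numbers for weaker inhibition), at 6 nM. Compound 2 `Cn1c(N2CCCC2)c(C#N)c2c(N)ncnc21`, which lacks the pyrazolylamino group altogether, gives 1910 nM in this assay, and compound 3 `CN(C)c1c(C#N)c2c(N)ncnc2n1C`, lacking it too, gives 3760 nM; the step from compound 2 to compound 3 is a 2.0-fold higher number from compound 2 to compound 3 (0.29 log units; within the scatter), a change at a different place. Compound 4 `C[C@@H]1CCCN1c1c(C#N)c2c(N)nc(Nc3cn(C)nc3Cl)nc2n1C` differs from compound 1 by 3-chloro-1-methyl-1H-pyrazol-4-yl in place of 1H-pyrazol-4-yl on a nitrogen on an aromatic ring. Going by the values given here, no measured step touches this group, so the only guide is that compound 2 and compound 3 without it give far higher numbers than compound 1. The substituted pyrazole is expected to keep most of that gain, so compound 4 is estimated at 10 nM, between 2 nM and 50 nM, a step of a 1.7-fold higher number from compound 1 to compound 4 (0.22 log units; within the scatter).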

Compound 4, half-maximal inhibitory concentration: 21 nM
The estimate for compound 4 lay 2.1-fold (0.32 log units) below the measured number; low and high end bracket the measured number.
By their numbers in this assay, from the lowest: compound 1; then compound 4; then compounds 2 and 3 (each within the scatter of the next).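

At this position, on a nitrogen on an aromatic ring, the replacement of 1H-pyrazol-4-yl by 3-chloro-1-methyl-1H-pyrazol-4-yl gives a 3.5-fold higher number from compound 1 to compound 4 (0.54 log units; beyond the scatter) in this assay, a modest loss beyond the scatter. The position therefore tolerates a substituted pyrazole with no hydrogen-bond donor, at a measurable but limited cost. Nothing available accounts for this step. Going by these compounds, the chlorine and the methyl enter together, so the share of each remains open. On these data alone, how a pyrazole carrying an amine or a carboxylic acid would read also remains open.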